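Aryl swap on the shared core: second pass

The source may report more compounds than this note shows. Statements on the series, on what has been measured and on what is new or still open speak of the compounds shown alone.

Of the compounds shown here, three on the shared core have been measured in a functional assay on A549 cells (Homo sapiens) for antiproliferative activity, read by MTT assay, with a stated time of 72 h; a lower number here means a stronger inhibitor, a higher number a weaker inhibitor. Compound 1 `CNC(=O)c1cc(Oc2ccc(NC(=O)c3cc4cccnc4n(-c4ccc(OC)cc4)c3=O)cc2)ccn1` gives 3110 nM in this assay. Compound 2 `CNC(=O)c1cc(Oc2ccc(NC(=O)c3cc4cccnc4n(-c4ccc(Br)cc4F)c3=O)cc2)ccn1` carries the change 4-bromo-2-fluorophenyl in place of 4-methoxyphenyl on an aromatic nitrogen and gives 1420 nM in this assay, a step of a 2.2-fold lower number from compound 1 to compound 2 (0.34 log units; beyond the scatter). Compound 3 `CCNC(=O)c1cc(Oc2ccc(NC(=O)c3cc4cccnc4n(-c4ccc(OC)cc4)c3=O)cc2)ccn1` differs from compound 1 by methyl in place of hydrogen on a saturated chain carbon bound to an amide-type nitrogen. In this assay compound 3 gives 2010 nM, a step of a 1.5-fold lower number from compound 1 to compound 3 (0.19 log units; within the scatter). Compound 4 `CCNC(=O)c1cc(Oc2ccc(NC(=O)c3cc4cccnc4n(-c4ccc(Br)cc4F)c3=O)cc2)ccn1` is not yet measured; it carries the same change, (4-bromo-2-fluorophenyl in place of 4-methoxyphenyl on an aromatic nitrogen), at the same place, made on the core of compound 3. Since the cores of compound 1 and compound 3 differ only by methyl in place of hydrogen on a saturated chain carbon bound to an amide-type nitrogen, and that step stayed within scatter, the measured step of a 2.2-fold lower number from compound 1 to compound 2 (0.34 log units; beyond the scatter) is taken as the guide, and the same change is expected to give about a 2.2-fold lower number from compound 3 to compound 4 (0.34 log units; beyond the scatter). Compound 4 is therefore estimated at 910 nM in this assay, most likely between 450 nM and 1800 nM.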

Compound 4, half-maximal inhibitory concentration: 1820 nM
Compound 4: middle estimate off by 2.0-fold (0.30 log units), on the low side; measured number outside the range, above it.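

In this assay, 4-bromo-2-fluorophenyl in place of 4-methoxyphenyl on the core of compound 3 gives a step within the scatter (a 1.1-fold lower number from compound 3 to compound 4 (0.04 log units; within the scatter)), whereas the same change on the core of compound 1 gave a step beyond it. This neither shows that the change carries over from one core to the other nor shows that it fails to, since the two steps cannot be told apart: the same change on two cores in this assay, a 2.2-fold lower number (0.34 log units; beyond the scatter) from compound 1 to compound 2 and a 1.1-fold lower number (0.04 log units; within the scatter) from compound 3 to compound 4, 2.0-fold (0.30 log units) apart, within the scatter of two such steps. The methyl step on the 4-bromo-2-fluorophenyl core (a 1.3-fold higher number from compound 2 to compound 4 (0.11 log units; within the scatter)) reads the same way: the same change on two cores in this assay, a 1.5-fold lower number (0.19 log units; within the scatter) from compound 1 to compound 3 and a 1.3-fold higher number (0.11 log units; within the scatter) from compound 2 to compound 4, 2.0-fold (0.30 log units) apart, within the scatter of two such steps.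

The compounds shown leave open whether the change behaves alike with a longer chain on the amide, such as propyl. As far as these compounds go, how an unsubstituted phenyl on the aromatic nitrogen compares also remains open.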